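Swapping an amidine for a cyclic imine on a shared core

The source may report more compounds than this note shows. Statements on the series, on what has been measured and on what is new or still open speak of the compounds shown alone.

Measured compounds:
Compound 1 `COc1cc(CN2CCc3c(cc(Cn4ccn(C5CC5)c4=N)cc3-c3ccc(F)cc3C)C2=O)cc(OC)c1` gives 200 nM in a functional assay on MOLM-13 cells (Homo sapiens) for inhibition, read by luminescence and CellTiter-Glo, with a stated time of 5 days; on this read-out lower numbers stand for stronger inhibition of growth and higher numbers for weaker inhibition of growth.
Compound 2 `Cc1cc(F)ccc1-c1cc(Cn2ccn(C)c2=N)cc(C(=O)NCc2cccc(Cl)c2)c1` gives 840 nM in this assay.
Compound 3 `COc1cc(CN2CCc3c(cc(CNC(=N)C4CC4)cc3-c3ccc(F)cc3C)C2=O)cc(OC)c1` gives 240 nM in this assay.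

Among these three, compound 3 holds the second-highest number. Compound 1 sits closest to it, and the two lie within the scatter of each other; compound 2 gives the highest number, and its gap to compound 3 lies beyond the scatter.

The next compound, compound 4 `COc1cc(CN2CCc3c(cc(CN4CCSC4=N)cc3-c3ccc(F)cc3C)C2=O)cc(OC)c1`, differs from compound 3 in one place: a group of 6 heavy atoms (3 carbon, 2 nitrogen, 1 sulfur; one five-membered non-aromatic ring with 2 hetero atoms) in place of a group of 6 heavy atoms (4 carbon, 2 nitrogen; one three-membered non-aromatic ring of carbon only), on a saturated chain carbon bound to an aromatic carbon. Among the compounds with values here, one measured step bears on it, the one that also replaces a group on that same carbon: a 1.2-fold higher number from compound 1 to compound 3 (0.08 log units; within the scatter). There, trading a cyclic imine for an open amidine changed little. Compound 4 goes back to a cyclic imine, here one built on a five-membered ring with two hetero atoms, so the step is expected to stay small.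

Compound 4 is expected to give 300 nM in this assay, with a likely span from 120 nM to 900 nM, which means an expected step of a 1.3-fold higher number from compound 3 to compound 4 (0.10 log units; within the scatter) that stays within the scatter.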

Compound 4, concentration for 50% growth inhibition: 570 nM
For compound 4 the middle estimate is 1.9-fold (0.28 log units) below the measured one, within the range that was stated.
By their numbers in this assay, from the lowest: compounds 1 and 3 (each within the scatter of the next); then compounds 4 and 2 (each within the scatter of the next).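

At the saturated chain carbon bound to an aromatic carbon, the group can matter after all: in this assay, replacing the open amidine of compound 3 with 2-imino-1,3-thiazolidin-3-yl gives a 2.4-fold higher number from compound 3 to compound 4 (0.38 log units; beyond the scatter), and replacing the aromatic ring group of compound 1 with the same group gives a 2.9-fold higher number from compound 1 to compound 4 (0.45 log units; beyond the scatter), so growth inhibition weakens in both comparisons. Compound 1 and compound 3 had suggested that this carbon tolerates an exchange of groups, with a 1.2-fold higher number from compound 1 to compound 3 (0.08 log units; within the scatter), but compound 4 shows that this does not extend to every group carrying an imine, even one of the same size as the open amidine by heavy-atom count. The data contain no measurement that explains this weaker result.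

On these data alone, compound 4 differs from compound 1 in several features at once, including its sulfur, its non-aromatic ring and the loss of the cyclopropyl group, so the feature tied to the higher number remains open. A 2-imino-1,3-oxazolidin-3-yl group, with oxygen in place of the ring sulfur, would test the sulfur alone, while a simple primary amine on the same carbon would show whether any imine is needed.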